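Chloro in place of methoxy: expectations for compound 4

This account rests on a few compounds, and the source may have more. Where it says the series, first, only, none or still open, it means among the compounds named here.

In an ADME assay on HEK-293T cells (Homo sapiens) for inhibition, read by CCK-8 assay, with a stated time of 48 h, tested at 20 uM (a lower number here means less inhibition of growth, a higher number more inhibition of growth at the concentration tested), compound 1 `N#C/C(=C\c1ccccc1OS(=O)(=O)c1ccc(Cl)cc1)C(=O)Nc1nnc(Cc2cccc3ccccc23)s1` gives 16%, compound 2 `Cc1ccc(S(=O)(=O)Oc2ccccc2/C=C(\C#N)C(=O)Nc2nnc(Cc3ccc(Cl)cc3)s2)cc1` gives 20% and compound 3 `COc1ccc(S(=O)(=O)Oc2ccccc2/C=C(\C#N)C(=O)Nc2nnc(Cc3ccc(Cl)cc3)s2)cc1` gives 26%. Compound 3 thus stands within the scatter of both others. Compound 4 `N#C/C(=C\c1ccccc1OS(=O)(=O)c1ccc(Cl)cc1)C(=O)Nc1nnc(Cc2ccc(Cl)cc2)s1` departs from it by one change, chloro in place of methoxy on an aromatic carbon, para to a large group. Among the compounds with values here, the one measured step at this place, methoxy in place of methyl, is a number 6 percentage points higher from compound 2 to compound 3 (within the scatter), within the scatter. Compound 4 shares its (4-chlorophenyl)sulfonyl group with compound 1 at 16%, which differs from it elsewhere. No step beyond the scatter is therefore expected in this assay, and the estimated change is a number 4 percentage points lower from compound 3 to compound 4 (within the scatter). For compound 4 the expected value is 22%, with an estimated range of 12% to 33%.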

Compound 4, percent growth inhibition at one concentration: 14%
For compound 4 the middle estimate is 8 percentage points above the measured one; measured number inside the range.
By their numbers in this assay, from the lowest: compounds 4, 1, 2 and 3 (each within the scatter of the next, the first and the last beyond it).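

In this assay, within the data shown here, chloro in place of methoxy on this aromatic carbon gives the first step here beyond the scatter (a number 12 percentage points lower from compound 3 to compound 4 (beyond the scatter)), whereas chloro in place of methyl stays within it (a number 6 percentage points lower from compound 2 to compound 4 (within the scatter)). With the (4-chlorophenyl)sulfonyl group kept, 4-chlorophenyl in place of naphthalen-1-yl also stays within it (a number 2 percentage points lower from compound 1 to compound 4 (within the scatter)). No evidence at hand accounts for these steps. Open, going by these compounds, is how an amine on this aromatic carbon would read, and whether the methoxy-to-chloro step holds when naphthalen-1-yl replaces 4-chlorophenyl on the saturated chain carbon.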